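Aryl replacement at the fused core of compound 1

This account rests on a few compounds, and the source may have more. Where it says the series, first, only, none or still open, it means among the compounds named here.

Compound 1 `COc1ccc(S(=O)(=O)N2CCc3cccc(-c4ccc(F)nc4)c32)cc1` is measured in a functional assay on NCI-H460 cells (Homo sapiens) for inhibition, with a stated time of 72 h (a higher number here means a weaker inhibitor, a lower number a stronger inhibitor), at 135 nM, the lowest of the three numbers in hand. Compound 2 `COc1ccc(S(=O)(=O)N2CCc3cccc(-c4c(F)c(F)c(F)c(F)c4F)c32)cc1` carries a pentafluorophenyl group at the same position and gives 4760 nM in this assay, beyond the scatter from compound 1. Compound 3 `COc1ccc(S(=O)(=O)N2CCc3cccc(-c4cc(OC)c(OC)c(OC)c4)c32)cc1`, with a trimethoxyphenyl group, gives 6340 nM, again beyond the scatter from compound 1. Both heavily substituted rings thus stand far weaker than the 6-fluoropyridin-3-yl of compound 1.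

Compound 4 `COc1ccc(S(=O)(=O)N2CCc3cccc(-c4cccc(F)c4)c32)cc1` is not yet measured. Relative to compound 1 the change is 3-fluorophenyl in place of 6-fluoropyridin-3-yl on an aromatic carbon. The ring entering is a six-membered aromatic ring of carbon only with a single fluorine, so it stays closer to compound 1 than to compound 2 or compound 3. Among the compounds with values here, no step between measured compounds isolates this change, so the expectation rests on compound 1 alone. A small loss is expected, a 1.9-fold higher number from compound 1 to compound 4 (0.28 log units; within the scatter), within or just beyond the scatter. Compound 4 is estimated at 260 nM, between 70 nM and 1000 nM.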

Compound 4, half-maximal inhibitory concentration: 167 nM
Compound 4: middle estimate off by 1.6-fold (0.19 log units), on the high side, within the range that was stated.
By their numbers in this assay, from the lowest: compounds 1 and 4 (each within the scatter of the next); then compounds 2 and 3 (each within the scatter of the next).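

In this assay the exchange of 6-fluoropyridin-3-yl for 3-fluorophenyl is a 1.2-fold higher number from compound 1 to compound 4 (0.09 log units; within the scatter) and leaves the two compounds level, so at this position on the shared core the ring nitrogen and its hydrogen-bond acceptor are not required for a value in this range. Compound 4 at 167 nM also shows that a ring of carbon only can stand with compound 1, so the distance of compound 2 at 4760 nM and compound 3 at 6340 nM does not follow from the loss of the ring nitrogen. No measurement in hand explains why these rings behave as they do. On these data alone, whether the single fluorine matters stays open, as a plain phenyl would show. So does the reach of this position towards an amine or a carboxylic acid on the ring.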